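Amide-tail swap on the nitrobenzoxadiazole succinate series

A few compounds are considered here, and "the series" means these few. Any claim that something is new, unique, unknown or untested is made for them only; others in the source may bear on it.

Measured so far:
compound 1 `O=C(O)CCC(=O)OCCCCCCSc1ccc([N+](=O)[O-])c2nonc12` — 160 nM
compound 2 `O=C(CCC(=O)OCCCCCCSc1ccc([N+](=O)[O-])c2nonc12)Nc1ccc(F)c(Cl)c1` — 470 nM

In an assay on isolated protein for inhibition of glutathione S-transferase Mu 2 (Homo sapiens), with a stated time of 10 min (a lower number here means a stronger inhibitor, a higher number a weaker inhibitor), compound 1 gives 160 nM and compound 2 gives 470 nM. Among the compounds with values here, compound 2 thus holds the higher of the two numbers; the single step leading to it, a 2.9-fold higher number from compound 1 to compound 2 (0.47 log units; beyond the scatter), is modest yet beyond the scatter.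

Compound 3 `CN(C)CCNC(=O)CCC(=O)OCCCCCCSc1ccc([N+](=O)[O-])c2nonc12` differs from compound 2 by 2-(dimethylamino)ethyl in place of 3-chloro-4-fluorophenyl on an amide-type nitrogen. Within the data shown here, no measured step exchanges one amide substituent for another, so the only guidance is a 2.9-fold higher number from compound 1 to compound 2 (0.47 log units; beyond the scatter), which shows that altering this end of the chain moves this assay only modestly. A step of comparable size is therefore expected here, with its direction uncertain, and the estimate is kept close to the two known values. Compound 3 is estimated at 350 nM, with a range of 120 nM to 1000 nM. This estimate corresponds to the expected step of a 1.3-fold lower number from compound 2 to compound 3 (0.13 log units; within the scatter), not clearly beyond the scatter.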

Compound 3, half-maximal inhibitory concentration: 160 nM
Compound 3: middle estimate off by 2.2-fold (0.34 log units), on the high side, and the stated range covers the measured number.
By their numbers in this assay, from the lowest: compounds 1 and 3 (each within the scatter of the next); then compound 2.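

In this assay the amide position now shows movement in the opposite direction (a 2.9-fold lower number from compound 2 to compound 3 (0.47 log units; beyond the scatter)), with 2-(dimethylamino)ethyl in place of 3-chloro-4-fluorophenyl on the amide-type nitrogen. Against the carboxylic acid of compound 1, the (2-(dimethylamino)ethyl)amino tail shows no loss (no change at the digits printed from compound 1 to compound 3 (within the scatter)), so among these three compounds the higher number of compound 2 goes with the 3-chloro-4-fluorophenyl group and not with the amide link as such. No measured evidence bears on why the two amide substituents differ.

As far as these compounds go, whether an unsubstituted phenyl on the amide nitrogen would separate the ring from its chlorine and fluorine remains open. Also open, from the compounds shown here alone, is whether the dimethylamino nitrogen matters, which a plain butyl amide or a primary amine on the same ethyl chain would address.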